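This account rests on a few compounds, and the source may have more. Where it says the series, first, only, none or still open, it means among the compounds named here.

Measured so far in an ADME assay on BCBL1 cells (Homo sapiens) for cytotoxicity, with a stated time of 7 days; a higher number here means that more compound is tolerated, a lower number that less compound is tolerated:

Compound 1 (`CC(C)CNc1nc(N)nc2c1ncn2/C=C1/CC1(CO)CO`): > 20000 nM as a limit
Compound 2 (`CCCCSc1nc(N)nc2c1ncn2/C=C1/CC1(CO)CO`): > 20000 nM as a limit

Going by the values given here, compound 2 therefore has no exact number, only a limit, and the one other measured compound is in the same position. Compound 3 (`Nc1nc(SCc2ccccc2)c2ncn(/C=C3/CC3(CO)CO)c2n1`) carries phenyl in place of propyl on a saturated chain carbon bound to a sulfur, which turns butylsulfanyl into benzylsulfanyl (phenyl in place of propyl on a saturated chain carbon bound to a sulfur). Among the compounds with values here, the only measured step that bears on this is a step that the two limits leave unreadable from compound 1 to compound 2 and no size can be taken from it. The evidence amounts to the limit of > 20000 nM in this assay, at which 2 of the 2 values shown sit, and nothing more. Nothing measured points to a change in either direction in this assay so no step beyond the scatter is expected (estimated: a number no higher from compound 2 to compound 3 (the limit leaves the size open)). For compound 3 the estimated value is 20000 nM with an expected range from 9000 nM to 40000 nM. There is a good chance that compound 3 will also give only a limit.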

Compound 3, half-maximal cytotoxic concentration: > 20000 nM
Compound 3: a limit, no number; the forecaster's own chance of this, stated with the estimate: 75%; the middle value sits exactly at the limit.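

In this assay, going by these compounds alone, compound 1, compound 2 and compound 3 each give only a limit, and no step between them can be read. The compounds shown leave open whether isobutylamino, butylsulfanyl or benzylsulfanyl makes any difference to how much compound is tolerated beyond that limit.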